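Alkyne aryl variation on the shared core

A few compounds are considered here, and "the series" means these few. Any claim that something is new, unique, unknown or untested is made for them only; others in the source may bear on it.

Measured so far in a functional assay on NCI-H460 cells (Homo sapiens) for inhibition, read by sulforhodamine B assay, with a stated time of 48 h; on this read-out lower numbers stand for stronger inhibition of growth and higher numbers for weaker inhibition of growth:
compound 1 `COC(=O)c1sc2cc(C#Cc3cccc(N)c3)cnc2c1N` gives 11500 nM;
compound 2 `COC(=O)c1sc2cc(C#Cc3ccsc3)cnc2c1N` gives 24800 nM;
compound 3 `COC(=O)c1sc2cc(C#Cc3ccccc3)cnc2c1N` reaches only the assay limit, > 150000 nM.

Compound 3 stands weakest of the three on these numbers: both steps towards it are beyond the scatter, and its value is the limit of > 150000 nM in this assay, at which 1 of the 3 values shown sits, so only a bound and no number is known for it. Compound 4 `COC(=O)c1sc2cc(C#Cc3ccccn3)cnc2c1N` differs from compound 3 by pyridin-2-yl in place of phenyl on a triple-bonded carbon.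

Among the compounds with values here, two measured steps bear on this change. an at least 6.0-fold higher number from compound 2 to compound 3 (0.78 log units; beyond the scatter) shows that removing a ring heteroatom from the group on the triple-bonded carbon raises the number, and an at least 13-fold higher number from compound 1 to compound 3 (1.11 log units; beyond the scatter) shows that the unsubstituted phenyl is also the weaker end against the 3-aminophenyl. Returning a ring heteroatom, as a pyridin-2-yl, is therefore expected to bring the number back down below the limit of compound 3, a step of about an at least 5.0-fold lower number from compound 3 to compound 4 (0.69 log units; beyond the scatter). Compound 4 is accordingly estimated at 30000 nM in this assay, within a range from 8000 nM to 150000 nM.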

Compound 4, concentration for 50% growth inhibition: 34900 nM
Compound 4: the middle estimate sits 1.2-fold (0.07 log units) below what was measured; measured number inside the range.
By their numbers in this assay, from the lowest: compound 1; then compounds 2 and 4 (each within the scatter of the next). At a limit, above all of these: compound 3.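

In this assay, pyridin-2-yl in place of phenyl on a triple-bonded carbon brings the number off the limit: an at least 4.2-fold lower number from compound 3 to compound 4 (0.63 log units; beyond the scatter). The size of that step is only a bound, as the value of compound 3 is a limit: the limit of > 150000 nM in this assay, at which 1 of the 4 values shown sits.
Pyridin-2-yl and thiophen-3-yl are not told apart at this place, a 1.4-fold higher number from compound 2 to compound 4 (0.15 log units; within the scatter), while the 3-aminophenyl group keeps the lowest number of the series, a 3.0-fold higher number from compound 1 to compound 4 (0.48 log units; beyond the scatter), so neither ring with a hetero atom matches the phenyl ring that carries the amino group.

Going by these compounds, it remains open whether pyridin-3-yl or pyridin-4-yl would give a number like that of pyridin-2-yl. On these data alone, it also remains open whether the gain from the amino group on the phenyl ring carries over to a hydroxyl or a dimethylamino group in its place.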